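Extending the amino group of compound 1 by an acetamidoethyl chain

The source may hold more compounds than are shown below. What is called first, only, known or untested is meant among the compounds shown, and "the series" means these compounds.

Compound 1, `COc1ccc(-c2c(C)nc3c(N)cc(Cl)nn23)cc1OC`: in an assay on isolated protein for inhibition of phosphatidylinositol 4,5-bisphosphate 3-kinase catalytic subunit beta isoform (Homo sapiens) (a lower number here means a stronger inhibitor, a higher number a weaker inhibitor), compound 1 gives <= 10000 nM, a limit of the assay.
Compound 2, `COc1ccc(-c2c(C)nn3c(NCCNC(=O)C(C)C)cc(C)nc23)cc1OC`: in this assay compound 2 gives <= 10000 nM, also a limit.
Compound 3, `CC(=O)NCCNc1cc(Cl)nn2c(-c3cccc(S(=O)(=O)NC(C)C)c3)c(C)nc12`: in this assay compound 3 gives <= 10000 nM, again a limit.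

Compound 1 therefore stands nowhere in particular among the numbers shown: its value is a limit, and the two other values are limits as well, so that the limit of <= 10000 nM in this assay, at which 3 of the 3 values shown sit, is all the assay has reported so far. Among the measured compounds shown here, no two of the measured compounds differ in a single place, so no measured step exists from which the effect of a change on the shared core could be read.

Compound 4, `COc1ccc(-c2c(C)nc3c(NCCNC(C)=O)cc(Cl)nn23)cc1OC`, is the not yet measured compound. It differs from compound 1 by 2-acetamidoethyl in place of hydrogen on a nitrogen on an aromatic ring. For the measured compounds named here, compound 2 and compound 3 both carry a related two-carbon amide chain on the corresponding nitrogen of their cores, and both sit at the limit, which gives no direction for the step.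

For compound 4 in this assay the estimate is 3000 nM, within a range from 300 nM to 10000 nM. The step this estimate implies, a step that the limit leaves unreadable from compound 1 to compound 4, is expected to stay within the scatter of repeated measurements.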

Compound 4, half-maximal inhibitory concentration: <= 10000 nM
Compound 4: no number, only a limit; the forecaster's own chance of this, stated with the estimate: 55%; the middle value does not contradict the limit.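

In this assay compound 4 gives <= 10000 nM, a limit, and no step from compound 1 to compound 4 can be read, because the two compounds share one limit: the limit of <= 10000 nM in this assay, at which 4 of the 4 values shown sit.

The compounds shown leave open whether 2-acetamidoethyl in place of hydrogen changes inhibition at all.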